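From Compound 2 to Compound 3: A Chloro Substitution

This account rests on a few compounds, and the source may have more. Where it says the series, first, only, none or still open, it means among the compounds named here.

Compound 1 `O=c1c2c(Nc3ccccc3)nn(-c3ccccc3)c2nc(Nc2ccccc2)n1-c1ccccc1` gives 43.4% in a functional assay on the whole organism (strain Wistar albino) for inhibition, with Rattus norvegicus as the target, read by paw edema, with a stated time of 2 h, at a dose of 25 mg/kg by the oral route; on this read-out higher numbers stand for more inhibition at the one dose given (going by the name of the read-out) and lower numbers for less inhibition.
Compound 2 `NS(=O)(=O)c1ccc(-n2nc(Nc3ccccc3)c3c(=O)n(-c4ccccc4)c(Nc4ccccc4)nc32)cc1` gives 54.8% in this assay.

For the measured compounds named here, compound 2 stands highest of the two numbers in this assay, and the only measured step, a number 11.4 percentage points higher from compound 1 to compound 2 (beyond the scatter), came from sulfamoyl in place of hydrogen on an aromatic carbon. Compound 3 `NS(=O)(=O)c1ccc(-n2nc(Nc3ccc(Cl)cc3)c3c(=O)n(-c4ccccc4)c(Nc4ccccc4)nc32)cc1` differs from compound 2 by chloro in place of hydrogen on an aromatic carbon, set para to a large group. Going by the values given here, no measured step involves a chloro group, so nothing seen so far bears on this change. For compound 3 a step of a number 2.2 percentage points higher from compound 2 to compound 3 (within the scatter) is expected, none beyond the scatter. Compound 3 is estimated at 57%, between 42% and 72%.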

Compound 3, a percentage reported as inhibition, in the whole organism at one dose (the size of the read-out at that dose, not a potency): 56.3%
The estimate for compound 3 lay 0.7 percentage points above the measured number; the range from low to high includes it.
By their numbers in this assay, from the lowest: compound 1; then compounds 2 and 3 (each within the scatter of the next).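

In this assay the change from anilino to (4-chlorophenyl)amino comes out as a number 1.5 percentage points higher from compound 2 to compound 3 (within the scatter) and so this position, on a ring para to a large group, takes a chloro group with no step beyond the scatter. For the compounds shown here, this is the first reading at this position, since the earlier step concerned sulfamoyl at a different place on the shared core. No available evidence bears on this result.

On these data alone, it remains open whether a methoxy group, an amine or a carboxylic acid at this position would give a step beyond the scatter. As far as these compounds go, whether chloro elsewhere on the shared core would behave the same also stays open.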